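The compounds below may be only part of what the source reports. "The series", "measured", "known", "first", "only" and "open" are said of these compounds alone.

Measured in a functional assay on MDA-MB-231 cells (Homo sapiens) for antiproliferative activity, read by MTT assay, with a stated time of 48 h; on this read-out higher numbers stand for weaker inhibition and lower numbers for stronger inhibition:
- compound 1 `Cc1ccc2nc(-c3ccc(F)cc3)cc(C(=O)OCc3ccccc3)c2c1`: 13200 nM
- compound 2 `O=C(OCc1ccccc1)c1cc(-c2ccc(Cl)cc2)nc2cc(Cl)c(Cl)cc12`: > 100000 nM

Not yet measured:
- compound 3 `COc1ccc(-c2cc(C(=O)OCc3ccccc3)c3cc(Cl)c(Cl)cc3n2)cc1`

Compound 2 stands at > 100000 nM in this assay; this is a limit of the assay and not a number. For the measured compounds named here, compound 1, at 13200 nM, is the only compound here with a true number, and no single-change step connects it to compound 2.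

Compound 3 keeps everything in compound 2 except one group, going from 4-chlorophenyl to 4-methoxyphenyl: methoxy in place of chloro on an aromatic carbon, para to a large group (methoxy in place of chloro on an aromatic carbon).

Going by the values given here, no measured step shows what this change does in this assay, so any expectation is weakly grounded. A modest shift towards stronger inhibition is expected, with a further limit reading for compound 3 about as likely as a number. The estimate amounts to an expected at least 1.6-fold lower number from compound 2 to compound 3 (0.22 log units; that floor lies within the scatter). For compound 3 the estimated value is 60000 nM, with an expected range of 15000 nM to 120000 nM.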

Compound 3, half-maximal inhibitory concentration: 39200 nM
Estimate against measurement, compound 3: 1.5-fold (0.18 log units) above, within the range that was stated.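

With compound 3 at 39200 nM in this assay, the core of compound 2 now has a true number, and the position para to a large group is shown to respond to substitution: methoxy in place of chloro gives an at least 2.5-fold lower number from compound 2 to compound 3 (0.40 log units; beyond the scatter). Compound 2 stands at > 100000 nM, which is a limit of the assay and not a number. The full size of this change cannot be given, and the step reads only as a floor, because its starting point is that limit: the limit of > 100000 nM in this assay, at which 1 of the 3 values shown sits.

Going by these compounds, this is the only replacement at this place that can be read, so it remains open whether an amine, a hydroxyl group or a longer chain such as ethoxy would move the number further in this assay, or whether 4-methoxyphenyl is unusual among such groups. For the compounds shown here, no single-change step links compound 1 to compound 2 or compound 3, so the other differences in the core cannot be read, and the benzyl ester, shared by all three compounds, remains untested against a carboxylic acid or an amide.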